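This account rests on a few compounds, and the source may have more. Where it says the series, first, only, none or still open, it means among the compounds named here.

Compounds measured in a functional assay on HCT-116 cells (Homo sapiens) for antiproliferative activity, read by MTT assay, with a stated time of 48 h; on this read-out higher numbers stand for weaker inhibition and lower numbers for stronger inhibition:

Compound 1 `Cc1cnc(Nc2ccc(C(C)C)cc2)nc1Nc1nc2ccccc2s1`: in this assay compound 1 sits at a limit of the assay, > 50000 nM, not a number.
Compound 2 `NS(=O)(=O)c1ccc(Nc2ncc(F)c(Nc3nc4ccccc4s3)n2)cc1`: compound 2 gives 3260 nM.
Compound 3 `Cc1cnc(Nc2ccc(S(N)(=O)=O)cc2)nc1Nc1nc2ccccc2s1`: compound 3 gives 1660 nM.

Compound 3 holds the lowest of the two numbers, with compound 2 nearest to it, a gap within the scatter. Compound 4 `Cc1cnc(Nc2ccc(S(N)(=O)=O)cc2)nc1Nc1nc2ccc(F)cc2s1` differs from compound 3 by fluoro in place of hydrogen on an aromatic carbon. Within the data shown here, no measured step exchanges fluoro for hydrogen on the fused system. The step of a 2.0-fold lower number from compound 2 to compound 3 (0.29 log units; within the scatter) swaps methyl for fluoro elsewhere and is within the scatter, while an at least 30-fold lower number from compound 1 to compound 3 (1.47 log units; beyond the scatter) is large but concerns the sulfamoyl, which compound 4 keeps. A step within the scatter is therefore expected, a 1.1-fold lower number from compound 3 to compound 4 (0.04 log units; within the scatter). Compound 4 is expected to give about 1500 nM, between 500 nM and 4500 nM.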

Compound 4, half-maximal inhibitory concentration: 2010 nM
Compound 4: the middle estimate sits 1.3-fold (0.13 log units) below what was measured; low and high end bracket the measured number.
By their numbers in this assay, from the lowest: compounds 3, 4 and 2 (each within the scatter of the next). At a limit, above all of these: compound 1.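

Fluoro in place of hydrogen on an aromatic carbon of the fused system gives a 1.2-fold higher number from compound 3 to compound 4 (0.08 log units; within the scatter) in this assay and this is the only reading at this position among the compounds shown. The earlier steps shown here changed other parts of the molecule, whereas this one shows that a single fluoro here is tolerated, with compound 4 level with compound 3. Nothing measured here speaks to a cause for this step. As far as these compounds go, whether methoxy, an amine or a carboxylic acid at this position would read differently stays open. So does whether fluoro here would give the same result on the core of compound 2.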